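The source may hold more compounds than are shown below. What is called first, only, known or untested is meant among the compounds shown, and "the series" means these compounds.

Compound 1, `COc1ccc(-c2cc(O)c3cccnc3n2)cc1`, gives 20900 nM in a functional assay on MDA-N cells (Homo sapiens); a lower number here means a stronger inhibitor of growth, a higher number a weaker inhibitor of growth.
Compound 2, `COc1ccc(-c2cc(O)c3cc(C)cnc3n2)cc1`, gives 1700 nM in this assay.
Compound 3, `COc1cccc(-c2cc(O)c3c(C)ccnc3n2)c1`, gives < 10 nM in this assay.

Compound 2 and compound 1 share a core and differ in one place, (hydrogen in place of methyl on an aromatic carbon). That change brings a 12-fold higher number from compound 2 to compound 1 (1.09 log units; beyond the scatter), so the methyl on the core of compound 2 is worth a good deal in this assay. For compound 3 the value is a limit of the assay and not a number, (the limit of < 10 nM in this assay, at which 1 of the 3 values shown sits); it sits at the lower limit and is not a measured point. Compound 3 and compound 2 are built from the same atoms joined differently, and the difference between the two cores is not broken down here.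

Compound 4, `COc1cccc(-c2cc(O)c3cccnc3n2)c1`, has not yet been measured in this assay. It stands to compound 3 as compound 1 stands to compound 2: hydrogen in place of methyl on an aromatic carbon. The place is not the same in the two pairs. In compound 2 the methyl sits two atoms from the ring nitrogen, meta to a fused ring and para to a fused ring; in compound 3 it sits ortho to a fused ring, meta to a fused ring and opposite the ring nitrogen. It is therefore the same kind of change, not the same change. Among the measured compounds shown here, because the only measured example of it, a 12-fold higher number from compound 2 to compound 1 (1.09 log units; beyond the scatter), is large, compound 4 is expected to lie well above compound 3. Since the value of compound 3 is only a limit, the true starting point may sit lower than the limit itself, which widens the range. The step from compound 3 to compound 4 is estimated at an at least 6.0-fold higher number from compound 3 to compound 4 (0.77 log units; beyond the scatter). Compound 4 is expected to give about 60 nM in this assay, most likely between 8 nM and 400 nM.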

Compound 4, concentration for 50% growth inhibition: < 10 nM
Compound 4: only a limit was reported; the forecaster's own chance of this, stated with the estimate: 15%; at least 6.0-fold (0.77 log units) between middle value and limit.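

Compound 3 and compound 4 are both reported in this assay only as a limit of the assay and not as a number, so no step between them can be read: the limit of < 10 nM in this assay, at which 2 of the 4 values shown sit.

The compounds shown leave open what the methyl opposite the ring nitrogen in compound 3 is worth in this assay, and how that compares with the methyl on the core of compound 2.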